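The source may report more compounds than this note shows. Statements on the series, on what has been measured and on what is new or still open speak of the compounds shown alone.

Compound 3 `COc1ccc(NC(=O)c2cccc(/C=C3\CC(=O)N(c4ccc(C)cc4)C3=O)c2)cc1` is the reference point here. In an ADME assay on NCM460 cells (Homo sapiens) for cytotoxicity, read by MTT assay, with a stated time of 72 h (on this read-out lower numbers stand for stronger inhibition and higher numbers for weaker inhibition), compound 3 gives > 100000 nM, which is a limit of the assay rather than a number. Compound 1 `CCc1cccc(NC(=O)c2cccc(/C=C3\CC(=O)N(c4ccccc4)C3=O)c2)c1` gives > 100000 nM in this assay, also a limit. Compound 2 `CCCCCN1C(=O)C/C(=C\c2cccc(C(=O)Nc3cccc(CC)c3)c2)C1=O` gives > 100000 nM in this assay, again a limit. Among the measured compounds shown here, the one single-change comparison, a step that the two limits leave unreadable from compound 1 to compound 2, is therefore unreadable, since every value sits at the limit of > 100000 nM in this assay, at which 3 of the 3 values shown sit. Compound 4 `CCc1cccc(NC(=O)c2cccc(/C=C3\CC(=O)N(c4ccc(C)cc4)C3=O)c2)c1` carries 3-ethylphenyl in place of 4-methoxyphenyl on an amide-type nitrogen. For the measured compounds named here, no measured step bears on this change, and the measured series offers no step size to work from. Compound 4 is therefore expected to remain at the limit as well, with the step of a number no higher from compound 3 to compound 4 (the limit leaves the size open) expected to be nothing beyond the scatter. The estimate for compound 4 is 100000 nM, expected to fall between 40000 nM and 300000 nM.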

Compound 4, half-maximal inhibitory concentration: > 100000 nM
Compound 4 ended at the assay's limit (the forecaster's own chance of this, stated with the estimate: 85%); the middle value lies on the limit itself.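

Compound 4 gives > 100000 nM in this assay, which is a limit. Its steps to compound 1, compound 2 and compound 3 cannot be read: the limit of > 100000 nM in this assay, at which 4 of the 4 values shown sit.

The compounds shown leave open how far each lies past the limit, and whether any of these changes shifts the value at all.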